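Moving the bromine: 3-bromophenyl to 4-bromophenyl

This account rests on a few compounds, and the source may have more. Where it says the series, first, only, none or still open, it means among the compounds named here.

In a functional assay on PC-3 cells (Homo sapiens) for antiproliferative activity, read by MTT assay, with a stated time of 72 h (on this read-out higher numbers stand for weaker inhibition and lower numbers for stronger inhibition), compound 1 (`O=C(N/N=C/c1ccccc1)Nc1ccc(Oc2ccnc3[nH]ccc23)c(F)c1`) gives 7940 nM and compound 2 (`O=C(N/N=C/c1cccc(Br)c1)Nc1ccc(Oc2ccnc3[nH]ccc23)c(F)c1`) gives 4020 nM so the two numbers sit within the scatter of each other, and compound 2 cannot be ranked ahead of compound 1. Compound 3 (`O=C(N/N=C/c1ccc(Br)cc1)Nc1ccc(Oc2ccnc3[nH]ccc23)c(F)c1`) has the same atoms as compound 2, joined differently (4-bromophenyl in place of 3-bromophenyl on a carbon with a double bond to nitrogen). Among the compounds with values here, the only measured step bearing on this is the bromo-for-hydrogen change (a 2.0-fold lower number from compound 1 to compound 2 (0.30 log units; within the scatter)) and no measured step moves the bromo group. With so little to go on, no step beyond the scatter is expected in this assay for this change. The expected step is a 1.0-fold lower number from compound 2 to compound 3 (0.00 log units; within the scatter) and the uncertainty stays wide. The estimated value for compound 3 is 4000 nM with an expected range from 1800 nM to 9000 nM as a working figure.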

Compound 3, half-maximal inhibitory concentration: 920 nM
The estimate for compound 3 lay 4.3-fold (0.64 log units) above the measured number; the measured number lies below the stated range.
By their numbers in this assay, from the lowest: compound 3; then compounds 2 and 1 (each within the scatter of the next).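

In this assay the placement of the bromo group now separates compounds that hold the same atoms: 4-bromophenyl in place of 3-bromophenyl on a carbon with a double bond to nitrogen gives a 4.4-fold lower number from compound 2 to compound 3 (0.64 log units; beyond the scatter) and so moves the number beyond the scatter. Bromo in place of hydrogen, which stayed within the scatter as 3-bromophenyl in compound 2, gives an 8.6-fold lower number from compound 1 to compound 3 (0.94 log units; beyond the scatter) as 4-bromophenyl, so this change can only be read together with where the bromo group sits. Nothing at hand gives a reason for the difference between the two bromophenyl groups.

From the compounds shown here alone, whether the lower number belongs to bromine itself or to any group carried as in 4-bromophenyl stays open, and 4-chlorophenyl, 4-methoxyphenyl or 4-carboxyphenyl on the same carbon would bear on that. Going by these compounds, how 2-bromophenyl compares with the other two bromophenyl groups also stays open.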